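Removing a ring hydroxy from a sulfamoyl adenosine analogue

The source may report more compounds than this note shows. Statements on the series, on what has been measured and on what is new or still open speak of the compounds shown alone.

Of the compounds shown here, two have been measured so far. Compound 1 `Nc1ncnc2c1ncn2[C@@H]1CO[C@H](COS(=O)(=O)NC(=O)[C@@H]2CCCN2)[C@@H](O)C1` gives 2800 nM in a functional assay on PBMC cells (Homo sapiens) for inhibition; on this read-out lower numbers stand for stronger inhibition and higher numbers for weaker inhibition. Compound 2 `CSCC[C@H](N)C(=O)NS(=O)(=O)OC[C@H]1OC[C@@H](n2cnc3c(N)ncnc32)[C@H](O)[C@@H]1O` gives 5200 nM in this assay, and compound 2 stands alongside compound 1: the gap between their two numbers lies within the usual scatter of this measurement, so the two cannot be told apart on the numbers shown. Compound 3 `CSCC[C@H](N)C(=O)NS(=O)(=O)OC[C@H]1OC[C@@H](n2cnc3c(N)ncnc32)C[C@@H]1O` has not yet been measured. It differs from compound 2 in one place, (hydrogen in place of hydroxy on a saturated ring carbon), a hydrogen in place of hydroxy on a saturated ring carbon of the six-membered ring that carries the adenine and the large side chain. Within the data shown here, no measured pair shows this exact step, so the expected size of the change rests on a guess, and the step from compound 2 to compound 3 in this assay is expected to be modest, at most slightly toward weaker inhibition, a 1.5-fold higher number from compound 2 to compound 3 (0.19 log units; within the scatter). Compound 3 is therefore estimated at 8000 nM in this assay, with a likely range from 2500 nM to 25000 nM.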

Compound 3, half-maximal inhibitory concentration: 5500 nM
Beside the measured number, compound 3's estimate is 1.5-fold (0.16 log units) above it; measured number inside the range.
By their numbers in this assay, from the lowest: compounds 1, 2 and 3 (each within the scatter of the next).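

In this assay, among these compounds, the hydroxy on this saturated ring carbon is tested directly for the first time, and replacing it with hydrogen gives a 1.1-fold higher number from compound 2 to compound 3 (0.02 log units; within the scatter) so the two groups cannot be told apart at this position on this read-out. The exchange on the carbonyl carbon, 1-amino-3-(methylsulfanyl)propyl in place of pyrrolidin-2-yl, gives a 2.0-fold higher number from compound 1 to compound 3 (0.29 log units; within the scatter) so these two side chains also cannot be told apart in the compounds compared. Nothing available gives a reason for either result.

The compounds shown leave open whether a fluorine, a methoxy or an amine on this ring carbon would also match the hydroxy and the hydrogen. They also leave open what happens when the hydroxy on the neighbouring ring atom is replaced by hydrogen.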